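Boc-hydrazide variant of a thienopyrimidine lutropin receptor agonist

The source may hold more compounds than are shown below. What is called first, only, known or untested is meant among the compounds shown, and "the series" means these compounds.

Measured so far:
compound 1 `COc1cccc(-c2nc(SC)nc3sc(C(=O)NN)c(N)c23)c1`: 8.5%
compound 2 `COc1cccc(-c2nc(SC)nc3sc(C(=O)NCCO)c(N)c23)c1`: 20.5%

In a functional assay on HEK293 cells for agonist activity at lutropin-choriogonadotropic hormone receptor (Homo sapiens), read by cAMP accumulation (a lower number here means a smaller maximal response, a higher number a larger maximal response), compound 2 gives 20.5%, the higher of the two numbers, with compound 1 as its nearest neighbour at 8.5%. Within the data shown here, the single step between them, a number 12 percentage points higher from compound 1 to compound 2 (beyond the scatter), is the only measured change that bears on the present question. Compound 3 `COc1cccc(-c2nc(SC)nc3sc(C(=O)NNC(=O)OC(C)(C)C)c(N)c23)c1` differs from compound 2 in one place: (tert-butoxycarbonyl)amino in place of 2-hydroxyethyl on an amide-type nitrogen. This move returns an amino-type group to the amide nitrogen, as in compound 1, yet carries the tert-butoxycarbonyl group in addition, for which no measured comparison exists. Among the measured compounds shown here, since the only relevant step is a number 12 percentage points higher from compound 1 to compound 2 (beyond the scatter), a partial reversal of that step is expected, leaning back toward compound 1. For compound 3 a value of 12% is estimated, within 2% to 28%, which means an expected step of a number 8.5 percentage points lower from compound 2 to compound 3 (within the scatter) in this assay.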

Compound 3, largest response reached (reported as efficacy), in percent of the reference or control that the assay uses: 2.4%
Estimate against measurement, compound 3: 9.6 percentage points above, and the stated range covers the measured number.
By their numbers in this assay, from the lowest: compounds 3 and 1 (each within the scatter of the next); then compound 2.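

In this assay, (tert-butoxycarbonyl)amino in place of 2-hydroxyethyl on the amide-type nitrogen gives a number 18.1 percentage points lower from compound 2 to compound 3 (beyond the scatter), so this position does not keep the response of compound 2 with this larger substituent. Tert-butoxycarbonyl in place of hydrogen on the amine nitrogen gives a number 6.1 percentage points lower from compound 1 to compound 3 (within the scatter), so the added group cannot be told apart from the free amino group, and among the three compounds only 2-hydroxyethyl stands clear of the others. No measurement at hand accounts for these differences.

Going by these compounds, what stays open is whether the response of compound 2 depends on the terminal hydroxyl or on the chain itself, a question that a plain ethyl or a 3-hydroxypropyl group on the same nitrogen would address. On these data alone, it is also open whether an acetyl group on the amine nitrogen would match tert-butoxycarbonyl.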